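A few compounds are considered here, and "the series" means these few. Any claim that something is new, unique, unknown or untested is made for them only; others in the source may bear on it.

Measured compounds:
compound 1, `CC1=CC[C@H](C(C)(C)N=C=S)CC1`, in a functional assay on PC-3 cells (Homo sapiens) for inhibition, read by sulforhodamine B assay, with a stated time of 48 h; a higher number here means a weaker inhibitor of growth, a lower number a stronger inhibitor of growth: > 100000 nM; this is a limit of the assay, not a number
compound 2, `CC1=CC[C@H](C(C)(C)NC(=S)N/N=C/c2ccc(O)cc2)CC1`, in this assay: 53800 nM
compound 3, `CC1=CC[C@H](C(C)(C)NC(=S)N/N=C(\C)c2ccccc2)CC1`, in this assay: > 100000 nM; this too is a limit of the assay, not a number

Compound 3 stands at the limit of > 100000 nM in this assay, at which 2 of the 3 values shown sit. No numbered value exists for it, so any step from compound 3 can only be judged against that limit. Going by the values given here, compound 2 is the one compound of the three with a number; it differs from compound 3 in more than one place, so its value shows only what compound 2 itself does and supports no step.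

Compound 4, `COc1ccc(/C(C)=N/NC(=S)NC(C)(C)[C@H]2CC=C(C)CC2)cc1`, is reached from compound 3 by methoxy in place of hydrogen on an aromatic carbon. Among the compounds with values here, no measured step describes this change anywhere. The expectation is therefore a step of at most modest size in this assay, most likely none beyond the scatter, with compound 4 expected to remain near the limit of this assay. Compound 4 is estimated at 90000 nM, between 30000 nM and 300000 nM. This estimate corresponds to the expected step of an at least 1.1-fold lower number from compound 3 to compound 4 (0.04 log units; that floor lies within the scatter).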

Compound 4, concentration for total growth inhibition: > 100000 nM
Compound 4 ended at the assay's limit; the forecaster's own chance of this, stated with the estimate: 60%; middle value at least 1.1-fold (0.04 log units) away from the limit.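

No step can be read from compound 3 to compound 4, because in this assay both stand as limits of the assay, not numbers: the limit of > 100000 nM in this assay, at which 3 of the 4 values shown sit.

As far as these compounds go, whether methoxy in place of hydrogen on an aromatic carbon changes growth inhibition at all remains open.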